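The compounds below may be only part of what the source reports. "The series", "measured", "known", "first", "only" and "open" are said of these compounds alone.

The measured compounds are:
compound 1, `COc1cc(NC(=O)Nc2cc(Nc3ccc(C)c(F)c3)ncn2)cc(OC)c1`, which in a functional assay on NCI-H226 cells (Homo sapiens) for inhibition, read by MTT assay, with a stated time of 48 h, tested at 10 uM (on this read-out lower numbers stand for less inhibition and higher numbers for more inhibition at the one concentration tested (going by the name of the read-out)), gives 39.7%;
compound 2, `COc1cc(NC(=O)Nc2cc(Nc3cc(F)ccc3OC)ncn2)cc(OC)c1`, which in this assay gives 37.7%;
compound 3, `COc1cc(NC(=O)Nc2cc(Nc3cc(I)ccc3OC)ncn2)cc(OC)c1`, which in this assay gives 56.7%.

Compound 3 stands highest of the three numbers. Its nearest neighbour on this read-out is compound 1, which lies a number 17 percentage points higher from compound 1 to compound 3 (beyond the scatter); compound 2 is furthest, the step being a number 19 percentage points higher from compound 2 to compound 3 (beyond the scatter). Compound 1 and compound 2 themselves differ only by a number 2 percentage points lower from compound 1 to compound 2 (within the scatter).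

Compound 4, `COc1cc(NC(=O)Nc2cc(Nc3cc(C)cc(F)c3)ncn2)cc(OC)c1`, has not yet been measured. It differs from compound 3 in one place: 3-fluoro-5-methylphenyl in place of 5-iodo-2-methoxyphenyl on a nitrogen on an aromatic ring.

Two of the measured steps bear on this change. Compound 1 also carries a phenyl bearing fluoro and methyl on the nitrogen, and the step to compound 3 was a number 17 percentage points higher from compound 1 to compound 3 (beyond the scatter). Compound 2 carries fluoro where compound 3 carries iodo, and that step was a number 19 percentage points higher from compound 2 to compound 3 (beyond the scatter). Compound 4 returns to a fluoro-and-methyl phenyl without iodine or methoxy, so in this assay a fall beyond the scatter is expected, roughly back to the level of compound 1. The step is estimated as a number 16.7 percentage points lower from compound 3 to compound 4 (beyond the scatter). Compound 4 is therefore expected to give 40%, with a range from 28% to 52%.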

Compound 4, a percentage reported as inhibition, at one concentration (the size of the read-out at that concentration, not a potency): 35.3%
The estimate for compound 4 lay 4.7 percentage points above the measured number; low and high end bracket the measured number.
By their numbers in this assay, from the lowest: compounds 4, 2 and 1 (each within the scatter of the next); then compound 3.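

In this assay, replacing 5-iodo-2-methoxyphenyl on a nitrogen on an aromatic ring with 3-fluoro-5-methylphenyl gave a number 21.4 percentage points lower from compound 3 to compound 4 (beyond the scatter) and thus confirmed that a phenyl bearing fluoro and methyl need not carry a particular arrangement to stay at the lower level: the isomeric change from 3-fluoro-4-methylphenyl gave only a number 4.4 percentage points lower from compound 1 to compound 4 (within the scatter) and so shows no separation. The change from 5-fluoro-2-methoxyphenyl gave a number 2.4 percentage points lower from compound 2 to compound 4 (within the scatter) and likewise shows no separation, so among these four compounds the methoxy-bearing group with fluoro does not stand apart from either fluoro-and-methyl group, and only compound 3, with its 5-iodo-2-methoxyphenyl, lies beyond the scatter of the others. No measurement shown here accounts for why this one group stands apart.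

The compounds shown leave open whether iodo would hold the higher number without the methoxy, and whether bromo or chloro in its place on the 2-methoxyphenyl would follow compound 3 or compound 2. They also do not tell how a phenyl carrying a larger substituent, such as a morpholine or a carboxylic acid, would behave at this nitrogen.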